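Working notes: solubility across the shared core, compounds 1 to 3

The source may report more compounds than this note shows. Statements on the series, on what has been measured and on what is new or still open speak of the compounds shown alone.

Compound 1 `OCCC1CCN(c2nccnc2OC2CN(c3ccc4ccccc4n3)C2)CC1` and compound 2 `N#CC1CCN(c2nccnc2OC2CN(c3ccc4ccccc4n3)C2)CC1` share one core. Among the measured compounds shown here, in a physicochemical assay for solubility, in phosphate buffer, at pH 7.4 (a higher number here means a more soluble compound, a lower number a less soluble compound), compound 1 gives 84000 nM, and in this assay compound 2 gives 66000 nM; the only measured step is a 1.3-fold lower number from compound 1 to compound 2 (0.10 log units; within the scatter), so the two numbers sit alongside each other within the scatter. Compound 3 `c1ccc2nc(N3CC(Oc4nccnc4-c4ccncc4)C3)ccc2c1` carries the change (pyridin-4-yl in place of 4-cyanopiperidin-1-yl on an aromatic carbon). For the measured compounds named here, no measured step bears directly on this change: the step of a 1.3-fold lower number from compound 1 to compound 2 (0.10 log units; within the scatter) exchanges a substituent on the saturated ring, whereas here the whole saturated ring leaves and an aromatic ring enters on the core. Going by the values given here, with only that one within-scatter step in hand, the expectation for this assay rests on the size of the exchange alone, and a step of a 2.2-fold lower number from compound 2 to compound 3 (0.34 log units; beyond the scatter) is estimated, with wide uncertainty. Compound 3 is therefore expected to give about 30000 nM, within roughly 8000 nM to 100000 nM.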

Compound 3, solubility: 56000 nM
Compound 3: middle estimate off by 1.9-fold (0.27 log units), on the low side; measured number inside the range.
By their numbers in this assay, from the lowest: compounds 3, 2 and 1 (each within the scatter of the next).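

In this assay, pyridin-4-yl in place of 4-cyanopiperidin-1-yl on an aromatic carbon gives a 1.2-fold lower number from compound 2 to compound 3 (0.07 log units; within the scatter), and the same exchange against 4-(2-hydroxyethyl)piperidin-1-yl gives a 1.5-fold lower number from compound 1 to compound 3 (0.18 log units; within the scatter), so both steps stay within the scatter. The earlier pair varied only a substituent on the saturated ring, whereas these steps show that this position also tolerates replacing the whole six-membered non-aromatic ring with a six-membered aromatic ring, without a reading beyond the scatter. Nothing available explains why these numbers sit together.

Open, as far as these compounds go, is whether any group at this aromatic carbon moves the number beyond the scatter, for example an open-chain amine or a carboxylic acid. Also open, from the compounds shown here alone, is whether substituents on the pyridin-4-yl ring would do so.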